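The source may hold more compounds than are shown below. What is called first, only, known or untested is meant among the compounds shown, and "the series" means these compounds.

Of the compounds shown here, two have so far been measured in a functional assay on the whole organism with Mus musculus as the target; a lower number here means that less compound is needed, a higher number that more compound is needed for the effect. Compound 1, `CCCCN1CCC[C@@H]1CNC(=O)c1cc(S(N)(=O)=O)ccc1OC`, gives 92.3 mg/kg. Compound 2, `CCN1CCC[C@H]1CNC(=O)c1cc(S(N)(=O)=O)cc2c1O[C@@H](C)C2`, gives 5.7 mg/kg, which is the lower of the two numbers, and the gap between compound 2 and compound 1 is beyond the usual scatter of this assay, so compound 2 needs clearly less material for the same effect.

The next compound, compound 3, is `CCN1CCC[C@H]1CNC(=O)c1cc(S(N)(=O)=O)cc2c1O[C@H](C)C2`. Against compound 2 the change is this: the two compounds have the same atoms and bonds and differ only in configuration as drawn: 1 of 2 stereo elements differ; a stereocentre at a saturated ring carbon is drawn S in compound 2 and R in compound 3. Nothing is added and nothing is taken away; only the spatial arrangement at one ring carbon is reversed. Within the data shown here, no pair of measured compounds differing in a single place exists here, so there is no earlier step to lean on. A reversal of this kind can leave the dose almost unchanged or shift it either way; the step is expected to be a modest rise that might still fall within the scatter. Compound 3 is therefore expected to give about 12 mg/kg, with a plausible range from 3 mg/kg to 50 mg/kg. That expectation corresponds to a step of a 2.1-fold higher number from compound 2 to compound 3 (0.32 log units; beyond the scatter).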

Compound 3, dose for half-maximal effect: 11 mg/kg
Beside the measured number, compound 3's estimate is 1.1-fold (0.04 log units) above it, and the stated range covers the measured number.
By their numbers in this assay, from the lowest: compounds 2 and 3 (each within the scatter of the next); then compound 1.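

In this assay, among these compounds, reversing the stereocentre at this saturated ring carbon from S to R gives a 1.9-fold higher number from compound 2 to compound 3 (0.29 log units; within the scatter), the first step that can be read as a single change. Compounds 1 and 2 differ in more than one place, so they could not show what this ring carbon contributes on its own. Here, a step within the scatter means the two drawn configurations at this position cannot be told apart in this whole-organism test, and any difference between them would need more data to establish. The comparison is a clean one, with nothing else to account for: the fact that compounds 2 and 3 differ only in the configuration as drawn

On these data alone, the other stereo element is the same in compounds 2 and 3, so what a reversal there would do on its own remains open. Also open is how the dose would respond to a different group on this same ring carbon, such as a hydroxyl group or a longer chain, as the compounds shown vary only the spatial arrangement at this position.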